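Swapping Phenyl for Fluoro in a Growth-Inhibition Series

The source may report more compounds than this note shows. Statements on the series, on what has been measured and on what is new or still open speak of the compounds shown alone.

Among the compounds with values here, compound 3 `C=C1CC(Cn2ccc(=O)[nH]c2=O)(c2ccc(-c3ccccc3)cc2)OC1=O` gives 1320 nM in a functional assay on PC-3 cells (Homo sapiens) for inhibition (on this read-out higher numbers stand for weaker inhibition of growth and lower numbers for stronger inhibition of growth), the lowest number of the three measured so far, though its gap to compound 1 is within the scatter. Compound 1 `C=C1CC(Cn2cc(C)c(=O)[nH]c2=O)(c2ccc(-c3ccccc3)cc2)OC1=O` gives 2510 nM, and compound 2 `C=C1CC(Cn2cc(C)c(=O)[nH]c2=O)(c2ccc(F)cc2)OC1=O` gives 9120 nM. Compound 4 `C=C1CC(Cn2ccc(=O)[nH]c2=O)(c2ccc(F)cc2)OC1=O` has not yet been measured; it differs from compound 3 by fluoro in place of phenyl on an aromatic carbon. The same exchange has been recorded once: a 3.6-fold higher number from compound 1 to compound 2 (0.56 log units; beyond the scatter). The other recorded step, a 1.9-fold lower number from compound 1 to compound 3 (0.28 log units; within the scatter), concerns the methyl and does not bear on this change. A modest rise of similar size is therefore expected in this assay. For compound 4 the expected step is a 3.6-fold higher number from compound 3 to compound 4 (0.55 log units; beyond the scatter), which gives an estimate of 4700 nM with a range from 2000 nM to 11000 nM.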

Compound 4, concentration for 50% growth inhibition: 16200 nM
Estimate against measurement, compound 4: 3.4-fold (0.54 log units) below, and the stated range ends below it.
By their numbers in this assay, from the lowest: compounds 3 and 1 (each within the scatter of the next); then compounds 2 and 4 (each within the scatter of the next).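

In this assay the exchange of phenyl for fluoro gives a 12-fold higher number from compound 3 to compound 4 (1.09 log units; beyond the scatter), so the size of this step depends on the core that carries it: the same change on two cores in this assay, a 3.6-fold higher number (0.56 log units; beyond the scatter) from compound 1 to compound 2 and a 12-fold higher number (1.09 log units; beyond the scatter) from compound 3 to compound 4, 3.4-fold (0.53 log units) apart, beyond the scatter of two such steps. Hydrogen in place of methyl, read on the fluoro compounds, gives a 1.8-fold higher number from compound 2 to compound 4 (0.25 log units; within the scatter), which differs from the same change on the phenyl compounds: the same change on two cores in this assay, a 1.9-fold lower number (0.28 log units; within the scatter) from compound 1 to compound 3 and a 1.8-fold higher number (0.25 log units; within the scatter) from compound 2 to compound 4, 3.4-fold (0.53 log units) apart, beyond the scatter of two such steps. The two changes therefore do not act independently across these four compounds. As far as these compounds go, it remains open how an amine, a carboxylic acid or a longer chain on that aromatic carbon would fare, and whether the methyl would matter with them.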